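Fluorine on the base of a dioxolane cytidine pair

The source may hold more compounds than are shown below. What is called first, only, known or untested is meant among the compounds shown, and "the series" means these compounds.

Compound 2 `C[C@]1(CO)OCC(n2ccc(N)nc2=O)O1` stands at the edge of what the read-out reports: in a functional assay on CCRF-CEM cells (Homo sapiens) for inhibition (on this read-out higher numbers stand for weaker inhibition and lower numbers for stronger inhibition), compound 2 gives > 100000 nM, a limit of the assay and not a number. Compound 1 `C[C@]1(CO)OC[C@@H](n2cc(F)c(N)nc2=O)O1` fares the same way, as in this assay compound 1 gives > 100000 nM, again a limit. Both values therefore sit at the limit of > 100000 nM in this assay, at which 2 of the 2 values shown sit. Compound 3 `C[C@]1(CO)OCC(n2cc(F)c(N)nc2=O)O1` is not yet measured; it differs from compound 2 by fluoro in place of hydrogen on an aromatic carbon. For the measured compounds named here, no step between measured compounds is available. The step that the limit leaves unreadable from compound 2 to compound 3 is expected to be none beyond the scatter. Compound 3 is expected near 150000 nM, within 50000 nM to 500000 nM.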

Compound 3, half-maximal inhibitory concentration: > 100000 nM
Compound 3 was reported as a limit (the forecaster's own chance of this, stated with the estimate: 85%); the middle value lies beyond the limit too.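

Compounds 1, 2 and 3 all stand at a limit, so no step among them can be read: the limit of > 100000 nM in this assay, at which 3 of the 3 values shown sit.

As far as these compounds go, whether fluoro in place of hydrogen or the configuration drawn at the saturated ring carbon changes inhibition at all stays open in this assay.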